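Swapping an Amide for a Pyridine on the Ring

A few compounds are considered here, and "the series" means these few. Any claim that something is new, unique, unknown or untested is made for them only; others in the source may bear on it.

Compound 1, `CCO[C@H]1C[C@@H](c2coc3ccc(Br)cc3c2=O)N(c2ccccc2)O1`, gives 21500 nM.
Compound 2, `COC(=O)[C@@]1(C)C[C@@H](c2coc3ccc(Br)cc3c2=O)N(c2ccccc2)O1`, gives 9900 nM.
Compound 3, `NC(=O)[C@H]1C[C@@H](c2coc3ccccc3c2=O)N(c2ccccc2)O1`, gives > 60000 nM, which is a limit of the assay rather than a number.

All three were tested in a functional assay on A549 cells (Homo sapiens) for inhibition, read by sulforhodamine B assay, with a stated time of 48 h; a lower number here means a stronger inhibitor, a higher number a weaker inhibitor. Going by these compounds, compound 3 sits at the limit of > 60000 nM in this assay, at which 1 of the 3 values shown sits, so its true value is unknown beyond that. Compound 4, `O=c1c([C@@H]2C[C@H](c3ccncc3)ON2c2ccccc2)coc2ccccc12`, differs from compound 3 in one place: pyridin-4-yl in place of carbamoyl on a saturated ring carbon. Within the data shown here, no pair of measured compounds differs in a single place, so no measured step guides this change. Compound 4 is expected to be a stronger inhibitor than compound 3, with an estimated step of an at least 2.0-fold lower number from compound 3 to compound 4 (0.30 log units; that floor lies within the scatter), although the limit on compound 3 makes this size uncertain. Compound 4 is estimated at 30000 nM, between 8000 nM and 100000 nM.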

Compound 4, half-maximal inhibitory concentration: 19300 nM
Compound 4: the middle estimate sits 1.6-fold (0.19 log units) above what was measured; the range from low to high includes it.
By their numbers in this assay, from the lowest: compounds 2, 4 and 1 (each within the scatter of the next, the first and the last beyond it). At a limit, above all of these: compound 3.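

Pyridin-4-yl in place of carbamoyl on the saturated ring carbon next to the ring oxygen gives an at least 3.1-fold lower number from compound 3 to compound 4 (0.49 log units; beyond the scatter), so a change at this position can shift the number in this assay beyond the scatter. Compound 3 stands at a limit rather than a number, so this step gives only a floor: the limit of > 60000 nM in this assay, at which 1 of the 4 values shown sits.

Still open, going by these compounds, is how a phenyl, an amine or a carboxylic acid on this carbon would compare with pyridin-4-yl. Also open, on these data alone, is whether the same swap gives a similar step on a core carrying bromine, like that of compound 1.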